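The source may hold more compounds than are shown below. What is called first, only, known or untested is meant among the compounds shown, and "the series" means these compounds.

Measured compounds:
Compound 1 `CCCCCc1cc2ccccc2nc1-c1cn(CCC(F)(F)C(F)(F)C(F)(F)C(F)(F)C(F)(F)C(F)(F)C(F)(F)C(F)(F)F)nn1` gives in a functional assay on THP-1 cells (Homo sapiens) for cytotoxicity, read by MTT assay, with a stated time of 24 h (on this read-out higher numbers stand for weaker inhibition and lower numbers for stronger inhibition), the limit > 100 ug/mL.
Compound 2 `CCCCCc1cc2ccccc2nc1-c1cn(-c2ccc(F)cc2)nn1` gives in this assay the limit > 100 ug/mL.
Compound 3 `CCc1cc2ccccc2nc1-c1cn(-c2ccc(F)cc2)nn1` gives in this assay the limit > 100 ug/mL.

In this assay every value shown is a limit of the assay rather than a number. From compound 2 to compound 3 the change is hydrogen in place of propyl on a saturated chain carbon, two bonds along the chain from an aromatic carbon and the step is a step that the two limits leave unreadable from compound 2 to compound 3; both ends sit at a limit, so its size cannot be read. How the core of compound 1 differs from that of compound 2 is not broken down here.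

Compound 4 `CCc1cc2ccccc2nc1-c1cn(CCC(F)(F)C(F)(F)C(F)(F)C(F)(F)C(F)(F)C(F)(F)C(F)(F)C(F)(F)F)nn1` is not yet measured. It differs from compound 1 by hydrogen in place of propyl on a saturated chain carbon, two bonds along the chain from an aromatic carbon, the same change made from compound 2 to compound 3, at the same place. Going by the values given here, the expected step that the limit leaves unreadable from compound 1 to compound 4 from compound 1 to compound 4 is therefore estimated as small, because the limit of > 100 ug/mL in this assay, at which 3 of the 3 values shown sit, places all three measured values at the same limit and the one measured instance of this change did not move a compound away from it. Compound 4 is estimated at 150 ug/mL, most likely reported again only as a limit.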

Compound 4, half-maximal inhibitory concentration: > 100 ug/mL
Compound 4: a limit, no number; the forecaster's own chance of this, stated with the estimate: 85%; the middle value is on the limit's open side.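

In this assay compound 4 gives > 100 ug/mL as a limit of the assay and not a number. With compound 1 also at a limit, no new step can be read between compound 1 and compound 4. The compounds shown leave open whether swapping pentyl for ethyl on this core changes cytotoxicity at all.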